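From bromo to hydroxymethyl on a side chain

The source may report more compounds than this note shows. Statements on the series, on what has been measured and on what is new or still open speak of the compounds shown alone.

- Compound 1 `O=C(O)CCCn1c2ccc([N+](=O)[O-])cc2c(=O)n1Cc1ccccc1`: "not determined" (no result reported)
- Compound 2 `O=c1c2cc([N+](=O)[O-])ccc2n(CCO)n1Cc1ccccc1`: > 300000 nM
- Compound 3 `O=[N+]([O-])c1ccc2nn(Cc3ccccc3)c(OCCBr)c2c1`: "not determined" (no result reported)

In an ADME assay on Vero cells (Chlorocebus sabaeus) for inhibition, read by fluorescence and resazurin assay, with a stated time of 24 h (a higher number here means that more compound is tolerated, a lower number that less compound is tolerated), compound 3 has no single number to stand on. Compound 2 gives > 300000 nM, which is a limit of the assay and not a number. Compound 1 also lacks a number.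

Compound 4 `O=[N+]([O-])c1ccc2nn(Cc3ccccc3)c(OCCCO)c2c1` follows from compound 3 with one change, (hydroxymethyl in place of bromo on a saturated chain carbon, two bonds along the chain from an oxygen on an aromatic ring). The same difference reads 2-bromoethoxy to 3-hydroxypropoxy. With no number for compound 3, no size or direction of step in this assay can be stated, so the expectation rests only on (the limit of > 300000 nM in this assay, at which 1 of the 3 values shown sits). Compound 4 is expected near 200000 nM, with an estimated range of 50000 nM to 400000 nM.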

Compound 4, half-maximal cytotoxic concentration: > 300000 nM
Compound 4: a limit, no number (the forecaster's own chance of this, stated with the estimate: 45%); middle value at least 1.5-fold (0.17 log units) away from the limit.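

No step can be read between compound 3 and compound 4 in this assay. Compound 4 gives > 300000 nM, a limit and not a number. The compounds shown leave open how far hydroxymethyl in place of bromo shifts tolerance.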